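Nitro in place of methoxy: from compound 1 to compound 4

The source may hold more compounds than are shown below. What is called first, only, known or untested is meant among the compounds shown, and "the series" means these compounds.

In a functional assay on B16 cells (Mus musculus) for cytotoxicity, read by MTT assay, with a stated time of 72 h (a lower number here means a stronger inhibitor, a higher number a weaker inhibitor), compound 1 `COc1ccc(OC)c(C2=NN(C(C)=O)C(c3ccc(OC)c(OC)c3)C2)c1` gives 62000 nM, the highest of the two numbers shown. Compound 3 `COc1cc(C2=NNC(c3cc(OC)c(OC)c(OC)c3)C2)cc(OC)c1OC` gives 56000 nM, which sits within the scatter of compound 1. For compound 2 `COc1ccccc1C1CC(c2cc(OC)c(OC)c(OC)c2)=NN1C(C)=O` this assay reports only a limit, > 100000 nM; (the limit of > 100000 nM in this assay, at which 1 of the 3 values shown sits). Within the data shown here, no pair of measured compounds differs in a single place, so no measured step is available.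

Compound 4 `COc1ccc(OC)c(C2=NN(C(C)=O)C(c3ccc(OC)c([N+](=O)[O-])c3)C2)c1` differs from compound 1 by nitro in place of methoxy on an aromatic carbon. Among the measured compounds shown here, with no comparable step in the set, a step no larger than the scatter is expected in this assay, in no fixed direction. Compound 4 is expected to give about 50000 nM, between 15000 nM and 150000 nM. The estimated step of a 1.2-fold lower number from compound 1 to compound 4 (0.09 log units; within the scatter) is thus expected to stay within the scatter.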

Compound 4, half-maximal inhibitory concentration: 58000 nM
Compound 4: middle estimate off by 1.2-fold (0.06 log units), on the low side; the measured number falls inside the stated range.
By their numbers in this assay, from the lowest: compounds 3, 4 and 1 (each within the scatter of the next). At a limit, above all of these: compound 2.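

In this assay the step of a 1.1-fold lower number from compound 1 to compound 4 (0.03 log units; within the scatter) is the only single-place comparison shown, and it gives the series its first direct reading at this position. On this aromatic carbon, ortho to a methoxy group and meta to a large group, nitro in place of methoxy leaves the number within the scatter. No measurement shown bears on why this step is so small. As far as these compounds go, whether an amine or a carboxylic acid on the same carbon would also stay within the scatter remains open.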